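The source may hold more compounds than are shown below. What is called first, only, known or untested is meant among the compounds shown, and "the series" means these compounds.

Measured so far:
- Compound 1, `Cc1c(C(=O)c2ccccc2-c2ccccc2)oc2cc(-c3ccccc3)cc(O)c12`, gives 0.1 ug/mL in a functional assay on WI-38 VA13 cells (Homo sapiens) for cytotoxicity; on this read-out lower numbers stand for an effect already at smaller amounts and higher numbers for an effect only at larger amounts of compound.
- Compound 2, `COc1cc(C(F)(F)F)ccc1C(=O)c1oc2cc(-c3ccccc3)cc(O)c2c1C`, gives 0.26 ug/mL in this assay.

Both compounds share one core and differ only in the ring attached to the carbonyl. Of the two numbers shown, compound 2 gives the higher one; the gap to compound 1 is beyond the usual scatter of this kind of measurement, so compound 2 shows its effect only at a larger amount than compound 1 does.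

The next compound, compound 3, `COc1ccccc1C(=O)c1oc2cc(-c3ccccc3)cc(O)c2c1C`, is not yet measured. It differs from compound 2 in one place: hydrogen in place of trifluoromethyl on an aromatic carbon. In words, a hydrogen in place of a trifluoromethyl on an aromatic carbon, with the methoxy group kept. For the measured compounds named here, no measured pair shows this change on its own, so there is no step to lean on; the only guide is that compound 1 and compound 2 lie close together. The expectation for compound 3 is a step from compound 2 of about a 1.3-fold lower number from compound 2 to compound 3 (0.11 log units; within the scatter), within the usual scatter. The estimated value for compound 3 is 0.2 ug/mL, within a range from 0.07 ug/mL to 0.6 ug/mL.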

Compound 3, half-maximal effective concentration: 0.09 ug/mL
Compound 3: the middle estimate sits 2.2-fold (0.35 log units) above what was measured; measured number inside the range.
By their numbers in this assay, from the lowest: compounds 3 and 1 (each within the scatter of the next); then compound 2.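

In this assay, putting hydrogen in place of trifluoromethyl on the aromatic carbon that lies meta to a methoxy group and para to a large group gives a 2.9-fold lower number from compound 2 to compound 3 (0.46 log units; beyond the scatter), a modest step beyond the scatter, so the group on this carbon does matter and compound 3 shows its effect at a smaller amount. At the other place of change, methoxy in place of phenyl on an aromatic carbon gives a 1.1-fold lower number from compound 1 to compound 3 (0.05 log units; within the scatter), which lies within the scatter, so this read-out does not tell these two compounds apart. Nothing at hand gives a measured reason for either result.

The compounds shown leave open where other groups on the trifluoromethyl-bearing carbon, such as an amine, a carboxylic acid or a single chlorine atom, would fall relative to compound 2 and compound 3. For the compounds shown here, they also leave open whether the step from trifluoromethyl to hydrogen keeps its size when the methoxy group is replaced by another group, since this change appears in only one pair.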